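The source may hold more compounds than are shown below. What is called first, only, known or untested is meant among the compounds shown, and "the series" means these compounds.

Of the compounds shown here, two with a shared core have been measured in a functional assay on Daoy cells (Homo sapiens) for antiproliferative activity, read by trypan blue exclusion and crystal violet staining, with a stated time of 72 h; on this read-out lower numbers stand for stronger inhibition and higher numbers for weaker inhibition. Compound 1 `COc1ccc(C(NC(C)=O)c2cc(Cl)c3cccnc3c2O)cc1OC` gives 210 nM. Compound 2 `CCCC(=O)NC(c1ccc(C)cc1)c1cc(Cl)c2cccnc2c1O` gives 100 nM, the lower of the two numbers, and its gap to compound 1 lies beyond the scatter of repeated measurements. Compound 2 therefore stands as the stronger inhibitor of this pair.

Compound 3 `CCCC(=O)NC(c1ccccc1)c1cc(Cl)c2cccnc2c1O` has not yet been measured in this assay. It departs from compound 2 in one place, hydrogen in place of methyl on an aromatic carbon, which turns 4-methylphenyl into phenyl. For the measured compounds named here, no measured pair shows this change on its own, so the data give no direct guide to its size or direction. With only a single methyl leaving, no step beyond the scatter is expected. The expected step of a 1.2-fold higher number from compound 2 to compound 3 (0.08 log units; within the scatter) is slight and stays within the scatter. For compound 3 the expected value is 120 nM, with an estimated range of 45 nM to 320 nM.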

Compound 3, half-maximal inhibitory concentration: 110 nM
Compound 3: the middle estimate sits 1.1-fold (0.04 log units) above what was measured; low and high end bracket the measured number.
By their numbers in this assay, from the lowest: compounds 2, 3 and 1 (each within the scatter of the next, the first and the last beyond it).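

In this assay, for the compounds shown here, the change from 4-methylphenyl to phenyl can now be read on its own for the first time, and it gives a 1.1-fold higher number from compound 2 to compound 3 (0.04 log units; within the scatter). At this place, on an aromatic carbon para to a large group, the methyl can therefore give way to hydrogen with no change beyond the scatter, so within this pair the methyl is not required to keep the number near that of compound 2. No supporting measurement is available to account for this small step.

The compounds shown cover only methyl and hydrogen at this place, so it remains open whether a larger or different group, such as an ethyl, a methoxy, a chlorine, an amine or a carboxylic acid, would leave the number just as flat or shift it beyond the scatter. Going by these compounds, the step has also been read on only one amide chain, and whether the same change behaves alike with a shorter chain, a longer chain or a ring on the amide carbonyl remains unknown.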